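The source may report more compounds than this note shows. Statements on the series, on what has been measured and on what is new or still open speak of the compounds shown alone.

Measured in a functional assay on U-251 cells (Homo sapiens) for antiproliferative activity, read by MTT assay, with a stated time of 24 h; a lower number here means a stronger inhibitor, a higher number a weaker inhibitor:
- Compound 1 `C#CCOc1ccc2c(=O)c(-c3cc(OC)c(OC)cc3OC)coc2c1`: 6450 nM.
- Compound 2 `COc1cc(OC)c(-c2coc3cc(OCC(=O)c4cccc(C(F)(F)F)c4)ccc3c2=O)cc1OC`: > 10000 nM, a limit of the assay.
- Compound 3 `COc1cc(OC)c(-c2coc3cc(OCc4ccc(Br)cc4)ccc3c2=O)cc1OC`: 10000 nM.

Compound 2 has no exact value and stands only at the limit of > 10000 nM in this assay, at which 1 of the 3 values shown sits.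

Compound 4 `COc1cc(OC)c(-c2coc3cc(OCc4ccccc4C)ccc3c2=O)cc1OC` carries 2-methylphenyl in place of (3-(trifluoromethyl)phenyl)carbonyl on a saturated chain carbon bound to an oxygen on an aromatic ring.

The closest measured exchange at this place is a number no higher from compound 2 to compound 3 (the limit leaves the size open), where the limit leaves the size open. It brings in 4-bromophenyl, which like 2-methylphenyl is a substituted phenyl group. Starting from ethynyl in compound 1, the other two steps are a 1.6-fold higher number from compound 1 to compound 3 (0.19 log units; within the scatter), within the scatter, and an at least 1.5-fold higher number from compound 1 to compound 2 (0.19 log units; that floor lies within the scatter), whose floor lies within the scatter.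

Given compound 3 at 10000 nM, the expected result is an at least 1.1-fold lower number from compound 2 to compound 4 (0.04 log units; that floor lies within the scatter), a step no larger than the scatter can hide, though its direction, if any, would be towards a lower number. The estimated value for compound 4 is 9000 nM, with an expected range of 4000 nM to 20000 nM.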

Compound 4, half-maximal inhibitory concentration: 2000 nM
Compound 4: middle estimate off by 4.5-fold (0.65 log units), on the high side; measured number below the stated range.
By their numbers in this assay, from the lowest: compound 4; then compounds 1 and 3 (each within the scatter of the next).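

In this assay, the place on a saturated chain carbon bound to an oxygen on an aromatic ring now shows a change beyond the scatter, with a 3.2-fold lower number from compound 1 to compound 4 (0.51 log units; beyond the scatter) and a 5.0-fold lower number from compound 3 to compound 4 (0.70 log units; beyond the scatter) as the two exactly sized steps. The second step matters most: both compounds carry a substituted phenyl group here, so the outcome depends on which substituted phenyl is present, not merely on having one. The exchange of (3-(trifluoromethyl)phenyl)carbonyl for 2-methylphenyl gives an at least 5.0-fold lower number from compound 2 to compound 4 (0.69 log units; beyond the scatter), and that size is only a floor: the limit of > 10000 nM in this assay, at which 1 of the 4 values shown sits.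

Within the data shown here, with 2-methylphenyl as the only group giving a lower number, it remains open whether other substituted phenyl groups would do the same. Also open, going by these compounds, is how an amine or a carboxylic acid at this place would read in this assay.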